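A few compounds are considered here, and "the series" means these few. Any claim that something is new, unique, unknown or untested is made for them only; others in the source may bear on it.

Measured so far in a functional assay on FM3A cells (Mus musculus) for inhibition, read by cell counting, with a stated time of 2 days; a higher number here means a weaker inhibitor, a lower number a stronger inhibitor:
compound 1 `CCc1ccc(-c2nn3cc(-c4cccc(N)c4)nc3s2)cc1` — 8200 nM
compound 2 `C=C(Br)C(=O)Nc1cccc(-c2cn3nc(-c4ccccc4)sc3n2)c1` — 900 nM
compound 3 `C=C(Br)C(=O)Nc1cccc(-c2cn3nc(-c4cccs4)sc3n2)c1` — 370 nM

Compound 3 has the lowest number of the three; the nearest is compound 2, and the furthest is compound 1, both beyond the scatter. Compound 4 `C=C(Br)C(=O)Nc1cccc(-c2cn3nc(-c4ccc(CC)cc4)sc3n2)c1` differs from compound 3 in one place: 4-ethylphenyl in place of thiophen-2-yl on an aromatic carbon. Going by the values given here, the one step that bears on this is a 2.4-fold lower number from compound 2 to compound 3 (0.39 log units; beyond the scatter), where the six-membered carbon-only ring gave the higher number. Among the compounds with values here, compound 4 returns a six-membered carbon-only ring, now carrying an ethyl group; for the ethyl itself no step is on record, and compound 1 differs in more than one place, so its value is only a loose pointer. The expected step is therefore upward, of about the size seen before, a 2.3-fold higher number from compound 3 to compound 4 (0.36 log units; beyond the scatter). Compound 4 is estimated at 850 nM, range 300 nM to 2500 nM.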

Compound 4, half-maximal inhibitory concentration: 3300 nM
Beside the measured number, compound 4's estimate is 3.9-fold (0.59 log units) below it, outside the stated range (above it).
By their numbers in this assay, from the lowest: compound 3; then compound 2; then compound 4; then compound 1.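

In this assay the ethyl group itself raises the number at this position, with a 3.7-fold higher number from compound 2 to compound 4 (0.56 log units; beyond the scatter), so the loss is not only a matter of the six-membered carbon-only ring returning. The whole change from thiophen-2-yl to 4-ethylphenyl gives an 8.9-fold higher number from compound 3 to compound 4 (0.95 log units; beyond the scatter). Going by these compounds alone, with 4-ethylphenyl held fixed, (1-bromoethenyl)carbonyl on the nitrogen gives a 2.5-fold lower number from compound 1 to compound 4 (0.40 log units; beyond the scatter), the first one-place reading of that group.

Open, as far as these compounds go, is whether methyl or a longer chain such as butyl on the phenyl ring follows ethyl. Nothing at hand explains these steps.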